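Amide side chain change from compound 1 to compound 4

The compounds below may be only part of what the source reports. "The series", "measured", "known", "first", "only" and "open" are said of these compounds alone.

Values in an in vitro ADME assay on microsomes from liver (Homo sapiens) for metabolic stability, in the presence of a further agent that is not named here (a higher number here means faster removal of the compound, a lower number slower removal), for the measured compounds
- compound 1 `CC(C)(CO)CNC(=O)c1cc2cc(C#N)ccc2n1Cc1cccc(OC(F)(F)F)c1` gives 20 mL.min-1.g-1 
- compound 2 `CCOc1ccc(OC(F)(F)F)cc1Cn1c(C(=O)NCC(C)(C)CO)cc2cc(C#N)ccc21` gives 20 mL.min-1.g-1 
- compound 3 `CCCOc1cccc(Cn2c(C(=O)NCC(C)(C)CO)cc3cc(C#N)ccc32)c1` gives 10 mL.min-1.g-1 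

Compound 1 and compound 2 share the same number, and compound 3 stays within the scatter of compound 1. Ethoxy in place of hydrogen on an aromatic carbon gives no change at the digits printed from compound 1 to compound 2 (within the scatter) and propyl in place of trifluoromethyl on an oxygen on an aromatic ring gives a 2.0-fold lower number from compound 1 to compound 3 (0.30 log units; within the scatter) in this series.

Compound 4 `CC(O)CCNC(=O)c1cc2cc(C#N)ccc2n1Cc1cccc(OC(F)(F)F)c1` keeps the core of compound 1 and differs only in the amide chain: 2-hydroxypropyl in place of 1-(hydroxymethyl)-1-methylethyl on a saturated chain carbon bound to an amide-type nitrogen. Neither measured step touches that chain, so the data hold no direct test of this change and bear on it only as a guide to how far values have moved in the series. Both steps stay within the scatter, so no step beyond the scatter is expected in this assay here, and no direction can be favoured. The expected step is no change at the digits printed from compound 1 to compound 4 (within the scatter) on this reading. For compound 4 the estimated value is 20 mL.min-1.g-1, with an expected range from 10 mL.min-1.g-1 to 40 mL.min-1.g-1.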

Compound 4, intrinsic clearance in microsomes: < 6 mL.min-1.g-1
Compound 4 was reported as a limit; the forecaster's own chance of this, stated with the estimate: 5%; middle value at least 3.3-fold (0.52 log units) away from the limit.
By their numbers in this assay, from the lowest: compounds 3, 1 and 2 (each within the scatter of the next). At a limit, below all of these: compound 4.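

In this assay, the amide chain proves to be the first place in this series where a change moves the number beyond the scatter: 2-hydroxypropyl in place of 1-(hydroxymethyl)-1-methylethyl gives an at least 3.3-fold lower number from compound 1 to compound 4 (0.52 log units; beyond the scatter) on a saturated chain carbon bound to an amide-type nitrogen. The two earlier steps lie elsewhere in the molecule and stay within the scatter, while this one comes with one heavy atom fewer and the same hydrogen-bond donor and acceptor counts. Compound 4 is reported as a limit, so the step is a bound and its full size remains unread: the limit of < 6 mL.min-1.g-1 in this assay, at which 1 of the 4 values shown sits.

The compounds shown do not separate the effect of the heavy-atom count from that of the altered chain shape. From the compounds shown here alone, whether an amine, a carboxylic acid or a longer chain here would give a similar number remains open, as does whether this step carries over to compound 2 and compound 3.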